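The source may hold more compounds than are shown below. What is called first, only, known or untested is meant among the compounds shown, and "the series" means these compounds.

Working notes on the series. In a functional assay on MCF7 cells (Homo sapiens) for antiproliferative activity, read by MTT assay, with a stated time of 48 h (on this read-out higher numbers stand for weaker inhibition and lower numbers for stronger inhibition), compound 2 `COc1cc(C(=O)/C(C)=C/c2c[nH]c3ccccc23)cc([Se]C)c1OC` gives 59 nM, the lowest of the three numbers recorded; compound 1 `COc1ccc2c(/C=C/C(=O)c3cc(N)c(OC)c(OC)c3)cn(C)c2c1` gives 505 nM and compound 3 `COc1ccc2c(/C=C/C(=O)c3cc(OC)c(OC)c([N+](=O)[O-])c3)cn(C)c2c1` gives 1520 nM, both higher. Among the measured compounds shown here, the one measured step, a 3.0-fold higher number from compound 1 to compound 3 (0.48 log units; beyond the scatter), concerns a nitro in place of amino on an aromatic carbon and does not touch the ring altered here. Compound 4 `COc1ccc2c(/C=C(\C)C(=O)c3cc(OC)c(OC)c([Se]C)c3)c[nH]c2c1` differs from compound 2 by methoxy in place of hydrogen on an aromatic carbon of the fused six-membered ring. For the measured compounds named here, no measured step bears on this change, so the expectation is a step within the scatter. The estimated step is a 1.1-fold higher number from compound 2 to compound 4 (0.04 log units; within the scatter). Compound 4 is expected at 65 nM, range 25 nM to 170 nM.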

Compound 4, half-maximal inhibitory concentration: 35 nM
Compound 4: middle estimate off by 1.9-fold (0.27 log units), on the high side; low and high end bracket the measured number.
By their numbers in this assay, from the lowest: compounds 4 and 2 (each within the scatter of the next); then compound 1; then compound 3.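

In this assay, methoxy in place of hydrogen on an aromatic carbon of the fused six-membered ring gives a 1.7-fold lower number from compound 2 to compound 4 (0.23 log units; within the scatter) and so leaves the number within the scatter. Among the compounds shown here, this is the first reading on this ring, as the earlier step lay elsewhere and said nothing about this position. Nothing at hand accounts for the result.

Open, from the compounds shown here alone, is whether a hydroxyl group, a chlorine atom or a longer ether chain on this carbon would read like methoxy. Also open, going by these compounds, is how methoxy reads on the other carbons of this ring.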